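The source may report more compounds than this note shows. Statements on the series, on what has been measured and on what is new or still open speak of the compounds shown alone.

Measured so far in a functional assay on K562 cells (Homo sapiens) for antiproliferative activity, read by MTT assay and trypan blue exclusion, with a stated time of 72 h; a lower number here means a stronger inhibitor, a higher number a weaker inhibitor:
- compound 1, `COC(=O)c1ccc(C2SCC(=O)N2c2ccc(N3CCN(Cc4cccc(C)c4)CC3)cn2)c(OC)c1`: > 100000 nM
- compound 2, `COC(=O)c1ccc(C2SCC(=O)N2c2ccc(N3CCN(S(=O)(=O)c4ccccc4)CC3)cn2)c(OC)c1`: 65600 nM

Compound 1 is reported in this assay only as a limit, > 100000 nM. Among the compounds with values here, compound 2 is therefore the only compound of the pair with a number in this assay, and that number, 65600 nM, is where it stands. The other value shown, that of compound 1, is a limit. Within the data shown here, the one measured step, an at least 1.5-fold lower number from compound 1 to compound 2 (0.18 log units; that floor lies within the scatter), is known only as a floor because the limit of > 100000 nM in this assay, at which 1 of the 2 values shown sits, caps it.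

Compound 3, `COC(=O)c1ccc(C2SCC(=O)N2c2ccc(N3CCN(S(=O)(=O)c4c(C)cc(C)cc4C)CC3)cn2)c(OC)c1`, differs from compound 2 by 2,4,6-trimethylphenyl in place of phenyl on a sulfonyl sulfur. Among the measured compounds shown here, the single measured step changes a different place, so it does not bear on this change, and nothing among the measured compounds speaks to methyl groups on the sulfonyl-bound phenyl. No step beyond the scatter is expected, so the step to compound 3 is estimated at a 1.1-fold lower number from compound 2 to compound 3 (0.04 log units; within the scatter). Compound 3 is thus expected at 60000 nM, in the range 25000 nM to 150000 nM.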

Compound 3, half-maximal inhibitory concentration: 53500 nM
Compound 3: the middle estimate sits 1.1-fold (0.05 log units) above what was measured; the measured number falls inside the stated range.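

On the sulfonyl sulfur, 2,4,6-trimethylphenyl and phenyl cannot be told apart in this assay: a 1.2-fold lower number from compound 2 to compound 3 (0.09 log units; within the scatter). This place therefore accepts the larger aryl group with no change that can be read, which the earlier pair could not show. Replacing 3-methylbenzyl with (2,4,6-trimethylphenyl)sulfonyl gives an at least 1.8-fold lower number from compound 1 to compound 3 (0.27 log units; that floor lies within the scatter), and that step is known only as a floor because of the limit on compound 1: the limit of > 100000 nM in this assay, at which 1 of the 3 values shown sits.

Still open, on these data alone, is whether an amine or a carboxylic acid on this aryl ring, or a small alkyl chain in place of the ring on the sulfonyl sulfur, would move the number beyond the scatter. As far as these compounds go, the true size of the step away from 3-methylbenzyl also remains open, and so does whether any change at this place gives a step beyond the scatter.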